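This account rests on a few compounds, and the source may have more. Where it says the series, first, only, none or still open, it means among the compounds named here.

Measured compounds:
Compound 1, `COc1cc(N)c(Cl)cc1NC(=O)C1CCN(Cc2ccc(C)c(C)c2)CC1`: in a functional assay on the whole organism for antagonist activity, with Mus musculus as the target (on this read-out lower numbers stand for an effect already at smaller amounts and higher numbers for an effect only at larger amounts of compound), compound 1 gives > 8 mg/kg, which is a limit of the assay.
Compound 2, `CCN1CCC(C(=O)Nc2cc(Cl)c(N)cc2OC)CC1`: in this assay compound 2 gives > 10 mg/kg, also a limit of the assay.

Compound 2 thus stands only at a limit, namely (the limit of > 10 mg/kg in this assay, at which 1 of the 2 values shown sits). Compound 1 stands at the other one, (the limit of > 8 mg/kg in this assay, at which 1 of the 2 values shown sits). Going by the values given here, the single measured step, a step that the two limits leave unreadable from compound 1 to compound 2, is therefore not readable in size, as both of its ends are limits.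

Compound 3, `COc1cc(N)c(Cl)cc1NC(=O)C1CCN(Cc2ccsc2)CC1`, differs from compound 2 by thiophen-3-yl in place of methyl on a saturated chain carbon bound to an amine nitrogen in a ring. Among the compounds with values here, no measured step of readable size bears on this change; the only comparison, compound 1 with a 3,4-dimethylphenyl in the same place, also ended at a limit. In this assay, within the data shown here, no step of readable size is therefore expected, and the expected step is a step that the limit leaves unreadable from compound 2 to compound 3. Compound 3 is estimated at 12 mg/kg in this assay, with a range from 4 mg/kg to 40 mg/kg, most likely again reported only as a limit.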

Compound 3, dose for half-maximal effect: 3.4 mg/kg
Compound 3: middle estimate off by 3.5-fold (0.55 log units), on the high side; measured number outside the range, below it.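

At the saturated chain carbon bound to an amine nitrogen in a ring, the group carried decides whether a readable value appears in this assay: thiophen-3-yl in place of methyl gives an at least 2.9-fold lower number from compound 2 to compound 3 (0.46 log units; beyond the scatter), and thiophen-3-yl in place of 3,4-dimethylphenyl gives an at least 2.3-fold lower number from compound 1 to compound 3 (0.37 log units; beyond the scatter). Carrying 3,4-dimethylphenyl on this carbon, compound 1 still stands at a limit of the assay, so an aromatic ring there does not by itself give a readable value: the limit of > 8 mg/kg in this assay, at which 1 of the 3 values shown sits. Compound 2 also stands at a limit of the assay, and the step joining the two limits cannot be read: the limit of > 10 mg/kg in this assay, at which 1 of the 3 values shown sits.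

Open, as far as these compounds go, is whether unsubstituted phenyl, furan-3-yl or thiophen-2-yl on this carbon would match compound 3. Also open, from the compounds shown here alone, is how a longer chain between the amine nitrogen and the thiophene ring would shift the number in this assay.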